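The source may report more compounds than this note shows. Statements on the series, on what has been measured and on what is new or still open speak of the compounds shown alone.

In a functional assay (lung) for inhibition, with Cavia porcellus as the target (a higher number here means a weaker inhibitor, a lower number a stronger inhibitor), compound 3 `O=C(O)CC1(CCc2ccc(OCc3ccc4ccccc4n3)cc2)CCCC1` gives 60 nM, the lowest of the three numbers shown, though its gap to compound 1 `c1cc(OCCCc2nnn[nH]2)cc(OCc2ccc3ccccc3n2)c1`, which gives 79 nM, and to compound 2 `c1cc(CCCCc2nnn[nH]2)cc(OCc2ccc3ccccc3n2)c1`, which gives 105 nM, both fall within the scatter, so no order among the three can be claimed. Among the measured compounds shown here, the one measured step, a 1.3-fold higher number from compound 1 to compound 2 (0.12 log units; within the scatter), concerns a change in the chain between the aromatic ring and the 1H-tetrazol-5-yl group and does not bear on the change at hand. Compound 4 `c1ccc2nc(COc3ccc(CCC4(Cc5nnn[nH]5)CCCC4)cc3)ccc2c1` differs from compound 3 by 1H-tetrazol-5-yl in place of carboxy on a saturated chain carbon bound to a saturated ring carbon. For the measured compounds named here, no measured pair isolates this exchange: compounds 1 and 2 carry the 1H-tetrazol-5-yl group and compound 3 the carboxy group, but they differ in other places as well, and their values all lie within the scatter of one another. The only guidance is that every compound shown, whichever of the two groups it carries, returns a similar number in this assay. Compound 4 is therefore expected to return a similar number, with a 1.1-fold higher number from compound 3 to compound 4 (0.03 log units; within the scatter) amounting to nothing beyond the scatter. The estimate for compound 4 in this assay is 65 nM, within 25 nM to 170 nM.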

Compound 4, half-maximal inhibitory concentration: 37 nM
Compound 4: the middle estimate sits 1.8-fold (0.24 log units) above what was measured, within the range that was stated.
By their numbers in this assay, from the lowest: compounds 4, 3, 1 and 2 (each within the scatter of the next, the first and the last beyond it).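

The exchange now has a matched pair: in this assay the step reads a 1.6-fold lower number from compound 3 to compound 4 (0.21 log units; within the scatter), so at this position, on a saturated chain carbon bound to a saturated ring carbon, the two groups cannot be told apart. The earlier compounds shown here could not show this, as those carrying 1H-tetrazol-5-yl also differed from compound 3 in other places, whereas here the rest of the structure stays the same and only carboxy gives way to the five-membered aromatic ring. No accompanying measurement bears on why the two groups return such similar numbers.

The compounds shown leave open whether this place would tolerate other replacements for carboxy, such as a primary amide, a sulfonamide or a hydroxamic acid, or a basic group such as an amine. They also leave open whether a longer chain in place of (1H-tetrazol-5-yl)methyl would hold the number in this assay, and whether the same exchange on the shorter or longer chains of related compounds would give a step of similar size.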